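Stereocentre inversion at the hydroxyl carbon in azido phosphates

The source may hold more compounds than are shown below. What is called first, only, known or untested is meant among the compounds shown, and "the series" means these compounds.

In an assay on isolated protein for inhibition of sphingosine-1-phosphate lyase 1 (Homo sapiens), using Lineweaver-Burk analysis (on this read-out higher numbers stand for weaker inhibition and lower numbers for stronger inhibition), compound 1 `CCCCCCCCCCCCC/C=C/[C@H](O)[C@H](COP(=O)(O)O)N=[N+]=[N-]` gives 20400 nM, the second highest of the three numbers; compound 3 `CCCCCCCCCCCCCCC[C@@H](O)[C@H](COP(=O)(O)O)N=[N+]=[N-]` gives 19000 nM and compound 2 `CCCCCCCCCCCCCCC[C@@H](O)[C@@H](COP(=O)(O)O)N=[N+]=[N-]` gives 36700 nM, both within the scatter of compound 1. Compound 4 `CCCCCCCCCCCCC/C=C/[C@@H](O)[C@H](COP(=O)(O)O)N=[N+]=[N-]` keeps every atom and bond of compound 1 and differs only in configuration: the two compounds have the same atoms and bonds; at least one stereo element is drawn with a configuration in one of them and without one in the other: 1 of 4 stereo elements differ; a stereocentre at a saturated chain carbon is drawn S in compound 1 and R in compound 4. Within the data shown here, the single measured step of the same kind is a 1.9-fold lower number from compound 2 to compound 3 (0.29 log units; within the scatter), where the drawn stereo elements are characterised by the fact that one of compounds 2 and 3 is drawn with a defined configuration and the other without, at the place where they differ. That step stays within the scatter, so compound 4 is expected to show a 1.0-fold lower number from compound 1 to compound 4 (0.01 log units; within the scatter), a step not beyond the scatter. Compound 4 is therefore estimated at 20000 nM, with a range from 8000 nM to 50000 nM.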

Compound 4, inhibition constant: 9100 nM
For compound 4 the middle estimate is 2.2-fold (0.34 log units) above the measured one; measured number inside the range.
By their numbers in this assay, from the lowest: compound 4; then compounds 3, 1 and 2 (each within the scatter of the next).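

Configuration at the hydroxyl carbon registers with the unsaturated chain (a 2.2-fold lower number from compound 1 to compound 4 (0.35 log units; beyond the scatter)), giving the first step in the series beyond the scatter, though a modest one. The earlier step between saturated compounds (a 1.9-fold lower number from compound 2 to compound 3 (0.29 log units; within the scatter)) gave no such reading. The pair differs in configuration alone, and the only supporting record is structural: the fact that one of compounds 1 and 4 is drawn with a defined configuration and the other without, at the place where they differ.

On these data alone, whether inversion at the hydroxyl carbon also registers with a saturated chain stays open. As far as these compounds go, it is equally open whether the preference for the configuration of compound 4 would persist with an amine in place of the azide.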